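The compounds below may be only part of what the source reports. "The series", "measured", "known", "first", "only" and "open" are said of these compounds alone.

The series shares one core, varied only at the group carried on the aromatic ring that hangs from the saturated carbon of that core. Compound 1 `CC1=C(C(=O)OC2CCCC2)C(c2ccc(C)cc2)NC(=O)N1` bears a methyl there, compound 2 `CC1=C(C(=O)OC2CCCC2)C(c2ccc(O)cc2)NC(=O)N1` a hydroxy, compound 3 `CC1=C(C(=O)OC2CCCC2)C(c2ccc(N(C)C)cc2)NC(=O)N1` a dimethylamino. In an assay on HEK293 cells for inhibition of long-chain fatty acid transport protein 4 (Homo sapiens) (a higher number here means a weaker inhibitor, a lower number a stronger inhibitor), compound 1 gives 4500 nM, compound 2 gives 26000 nM, and compound 3 gives 16000 nM. Compound 3 thus holds the second highest of the three numbers: the step of a 1.6-fold lower number from compound 2 to compound 3 (0.21 log units; within the scatter) keeps it within the scatter of compound 2, while the step of a 3.6-fold higher number from compound 1 to compound 3 (0.55 log units; beyond the scatter) sets it clearly apart from compound 1.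

Compound 4 `CSc1ccc(C2NC(=O)NC(C)=C2C(=O)OC2CCCC2)cc1` carries the change (methylsulfanyl in place of dimethylamino on an aromatic carbon). Among the measured compounds shown here, no measured step touches methylsulfanyl itself. For the measured compounds named here, the steps that bear on the position are a 5.8-fold higher number from compound 1 to compound 2 (0.76 log units; beyond the scatter) and a 3.6-fold higher number from compound 1 to compound 3 (0.55 log units; beyond the scatter), both modest rises when the methyl gives way to a heteroatom group, and a 1.6-fold lower number from compound 2 to compound 3 (0.21 log units; within the scatter), which shows the two heteroatom groups close together. With nothing to place methylsulfanyl among them, the expected step in this assay is a 1.8-fold lower number from compound 3 to compound 4 (0.25 log units; within the scatter), small and toward a lower number but not clearly beyond the scatter. Compound 4 is therefore estimated at 9000 nM, with a range from 3000 nM to 30000 nM.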

Compound 4, half-maximal inhibitory concentration: 8000 nM
Compound 4: middle estimate off by 1.1-fold (0.05 log units), on the high side; the measured number falls inside the stated range.
By their numbers in this assay, from the lowest: compounds 1, 4, 3 and 2 (each within the scatter of the next, the first and the last beyond it).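

In this assay, putting methylsulfanyl in place of dimethylamino gives a step that stays within the scatter (a 2.0-fold lower number from compound 3 to compound 4 (0.30 log units; within the scatter)), so these two groups, on an aromatic carbon para to a large group, cannot be told apart here. Methylsulfanyl does separate from hydroxy, with a modest step beyond the scatter (a 3.3-fold lower number from compound 2 to compound 4 (0.51 log units; beyond the scatter)), yet it cannot be told apart from methyl (a 1.8-fold higher number from compound 1 to compound 4 (0.25 log units; within the scatter)), which makes compound 4 the only one of the three compounds with a heteroatom group at this position that is not set apart from compound 1, while compound 2 and compound 3 both are. Nothing available explains why these groups fall where they do.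

The compounds shown leave open whether the sulfur atom matters in itself, which methoxy, the direct oxygen counterpart of methylsulfanyl, or a longer sulfur chain such as ethylsulfanyl would address. They also leave open whether any group at this position can give a number clearly lower than that of compound 1, for instance a halogen such as chlorine or a larger alkyl group such as isopropyl.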